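A few compounds are considered here, and "the series" means these few. Any claim that something is new, unique, unknown or untested is made for them only; others in the source may bear on it.

Compound 2 `Cc1c(CO)c(CO)c2n1[C@@H](c1ccccc1)SC2` gives the lowest number of the three compounds measured in a functional assay on MCF7 cells (Homo sapiens) for cytotoxicity, read by MTT assay, with a stated time of 96 h (on this read-out lower numbers stand for stronger inhibition and higher numbers for weaker inhibition), at 600 nM. Compound 1 `Cc1c(CO)cc2n1[C@@H](c1ccccc1)SC2` gives 1900 nM in this assay, and compound 3 `Cc1c(CO)c(CO)c2n1CSC2` gives 21500 nM. The step of a 3.2-fold lower number from compound 1 to compound 2 (0.50 log units; beyond the scatter) shows that a hydroxymethyl in place of hydrogen on an aromatic carbon lowers the number, and the step of a 36-fold higher number from compound 2 to compound 3 (1.55 log units; beyond the scatter) shows that hydrogen in place of phenyl on the saturated ring carbon raises it sharply.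

Compound 4 `OCc1c(CO)c(-c2ccccc2)n2c1CS[C@@H]2c1ccccc1` differs from compound 2 in one place: phenyl in place of methyl on an aromatic carbon. Among the compounds with values here, no measured step touches this position. The step from compound 2 to compound 3 concerns a phenyl on the saturated ring carbon, not on the aromatic carbon, so it tells only that a phenyl within the shared core can matter strongly, without showing the direction for this new site. The step from compound 1 to compound 2 concerns a hydroxymethyl and bears on the question even less. The step of a 1.3-fold higher number from compound 2 to compound 4 (0.12 log units; within the scatter) is therefore expected to be modest, and it could fall either way, so the range is wide. Compound 4 is estimated at 800 nM, with a range from 200 nM to 4000 nM.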

Compound 4, half-maximal inhibitory concentration: 70200 nM
Compound 4: middle estimate off by 88-fold (1.94 log units), on the low side; measured number above the stated range.
By their numbers in this assay, from the lowest: compound 2; then compound 1; then compound 3; then compound 4.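

In this assay, phenyl in place of methyl on the aromatic carbon next to the ring nitrogen gives a 120-fold higher number from compound 2 to compound 4 (2.07 log units; beyond the scatter), so this site, which no earlier step had touched, proves highly sensitive to the group it carries, and of the two groups shown, methyl goes with the far lower number. The direction also differs from that of the other phenyl change: phenyl on the saturated ring carbon goes with the lower number in the pair of compound 2 and compound 3, whereas phenyl on this aromatic carbon goes with the higher number in the pair of compound 2 and compound 4, so the presence of a phenyl does not act the same way at both sites. Nothing available here accounts for the size or direction of this step.

The compounds shown leave open whether hydrogen, ethyl, an amine or a carboxylic acid on this aromatic carbon would give a number closer to that of compound 2 or to that of compound 4. They also leave open how phenyl at this site behaves when the saturated ring carbon carries hydrogen, as it does in compound 3.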